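The source may hold more compounds than are shown below. What is called first, only, known or untested is meant among the compounds shown, and "the series" means these compounds.

Compound 1 `CC(=O)c1ccc2c(c1O)[C@@H]1c3c(ccc4c(=O)c(C)c(C)oc34)OC[C@@H]1C(C)(C)O2` carries an acetyl group on the shared core. In a functional assay on MDA-MB-231 cells (Homo sapiens) for cytotoxicity, read by MTT assay (a higher number here means a weaker inhibitor, a lower number a stronger inhibitor), compound 1 gives only a limit, > 100000 nM. Compound 2 `Cc1oc2c3c(ccc2c(=O)c1C)OC[C@H]1[C@@H]3c2c(ccc(C(=O)Cc3ccccc3)c2O)OC1(C)C` likewise gives only a limit in this assay, > 100000 nM. Compound 3 `Cc1oc2c3c(ccc2c(=O)c1C)OC[C@H]1[C@@H]3c2c(ccc(C(=O)c3ccccc3)c2O)OC1(C)C` also gives only a limit in this assay, > 100000 nM. The steps a step that the two limits leave unreadable from compound 1 to compound 2, a step that the two limits leave unreadable from compound 1 to compound 3 and a step that the two limits leave unreadable from compound 2 to compound 3 therefore cannot be read, because of the limit of > 100000 nM in this assay, at which 3 of the 3 values shown sit.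

Compound 4 `CC(=O)c1ccc2c(c1O)[C@@H]1c3c(ccc4c(=O)c(-c5ccccc5)c(C)oc34)OC[C@@H]1C(C)(C)O2` differs from compound 1 by phenyl in place of methyl on an aromatic carbon, on an aromatic carbon of a six-membered aromatic ring with one oxygen, ortho to a methyl group. Within the data shown here, no measured step bears readably on this change, so no direction can be drawn. Compound 4 is expected at 100000 nM, between 30000 nM and 300000 nM, most probably again reported only as a limit. The expected step of a number no higher from compound 1 to compound 4 (the limit leaves the size open) is estimated to stay within the scatter.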

Compound 4, half-maximal inhibitory concentration: 46800 nM
Beside the measured number, compound 4's estimate is 2.1-fold (0.33 log units) above it, within the range that was stated.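

Phenyl in place of methyl on an aromatic carbon of the six-membered aromatic ring with one oxygen gives, in this assay, an at least 2.1-fold lower number from compound 1 to compound 4 (0.32 log units; beyond the scatter), the only readable step shown. The earlier changes, all on the carbonyl side chain, could not be read, so this is the only position shown where a change moves the number beyond the scatter. Its full size stays open, because compound 1 stands only at a limit: the limit of > 100000 nM in this assay, at which 3 of the 4 values shown sit.

On these data alone, whether an ethyl group, a pyridine ring or a phenyl carrying an amine would act like phenyl here stays open. So does whether the change holds with the benzoyl group of compound 3.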